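Removing the Methyl from the Aryl Ether of Compound 1

This account rests on a few compounds, and the source may have more. Where it says the series, first, only, none or still open, it means among the compounds named here.

Compound 1 `COc1ccc(-c2cnc(NC(=O)CCCCCCNC(=O)C(O)(O)C(F)(F)F)s2)cc1` is one of three close analogues that share the same chain. In an assay on isolated protein for inhibition of histone deacetylase 4 (Homo sapiens), read by chemiluminescence, with a stated time of 3 h (a lower number here means a stronger inhibitor, a higher number a weaker inhibitor), compound 1 gives 2500000 nM. Compound 2 `COc1ccc(NC(=O)CCCCCCNC(=O)C(O)(O)C(F)(F)F)cc1` gives 1600000 nM in this assay, and compound 3 `COc1ccc2sc(NC(=O)CCCCCCNC(=O)C(O)(O)C(F)(F)F)nc2c1` gives 1900000 nM. The three numbers lie within the scatter of one another, so compound 1 cannot be set apart from either of the other two on this evidence. The next step leads to compound 4 `O=C(CCCCCCNC(=O)C(O)(O)C(F)(F)F)Nc1ncc(-c2ccc(O)cc2)s1`, which differs from compound 1 by hydrogen in place of methyl on an oxygen on an aromatic ring. Going by the values given here, no pair of measured compounds isolates this particular change, and the three measured compounds, with quite different aromatic parts, all land in the same narrow band. On that basis the expected step is a 1.3-fold lower number from compound 1 to compound 4 (0.10 log units; within the scatter), within the scatter and with no clear direction. For compound 4 the estimate in this assay is 2000000 nM, with a range from 800000 nM to 5000000 nM.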

Compound 4, half-maximal inhibitory concentration: 2300000 nM
For compound 4 the middle estimate is 1.2-fold (0.06 log units) below the measured one, and the stated range covers the measured number.
By their numbers in this assay, from the lowest: compounds 2, 3, 4 and 1 (each within the scatter of the next).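

Going by these compounds alone, the step to the 4-hydroxyphenyl group gives the first direct reading of this change: in this assay, hydrogen in place of methyl on an oxygen on an aromatic ring gives a 1.1-fold lower number from compound 1 to compound 4 (0.04 log units; within the scatter), which lies within the scatter. The earlier compounds shown here differ in their aromatic parts and offered no single-change pair, whereas this pair shows that, on the core of compound 1, going from methoxy to hydroxy produces no readable shift in either direction. No measurement shown here offers an explanation for this result.

From the compounds shown here alone, whether an amine, a carboxylic acid or a longer chain on this position would move the number beyond the scatter remains open. Also open, going by these compounds, is whether the same change would read the same way on the cores of compound 2 and compound 3, which also carry a methoxy group.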